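The compounds below may be only part of what the source reports. "The series", "measured", "known", "first", "only" and "open" are said of these compounds alone.

For the measured compounds named here, compound 3 `CC(C(=O)NCc1ccc(C(F)(F)F)nc1SCCC(=O)N1CCCC1)c1ccc(NS(C)(=O)=O)c(F)c1` is one of three compounds measured in an assay on CHO-K1 cells for antagonist activity at transient receptor potential cation channel subfamily V member 1 (Homo sapiens), read by FLIPR; a lower number here means a stronger inhibitor, a higher number a weaker inhibitor. Compound 1 `CC(C(=O)NCc1ccc(C(F)(F)F)nc1SCCCN1CCCCC1)c1ccc(NS(C)(=O)=O)c(F)c1` gives 3 nM and compound 2 `CC1CCN(CCCSc2nc(C(F)(F)F)ccc2CNC(=O)C(C)c2ccc(NS(C)(=O)=O)c(F)c2)CC1` gives 2.9 nM, while compound 3 gives 85 nM, the highest of the three numbers, which makes it the weakest inhibitor of the set. Compound 4 `CC(C(=O)NCc1ccc(C(F)(F)F)nc1S(=O)(=O)C1CCCCC1)c1ccc(NS(C)(=O)=O)c(F)c1` has not been measured. It differs from compound 3 in one place: cyclohexylsulfonyl in place of (2-((pyrrolidin-1-yl)carbonyl)ethyl)sulfanyl on an aromatic carbon. The chain carrying the (pyrrolidin-1-yl)carbonyl is thus gone, and the sulfur becomes part of a cyclohexylsulfonyl group. Going by the values given here, two measured steps concern the same position. The step of a 28-fold higher number from compound 1 to compound 3 (1.45 log units; beyond the scatter) and the step of a 29-fold higher number from compound 2 to compound 3 (1.47 log units; beyond the scatter) both show that what sits on this sulfur can move the number a long way, and that the chain in compound 3 is the worst of those tried. Among the compounds with values here, no measured compound carries a sulfonyl or a cyclohexyl, so the direction for compound 4 is uncertain. Compound 4 is expected to give 40 nM, within 6 nM to 300 nM. The expected step of a 2.1-fold lower number from compound 3 to compound 4 (0.33 log units; beyond the scatter) is estimated to recover part of the ground lost at this position.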

Compound 4, inhibition constant: "not active" (no number reported)
The entry for compound 4 holds no number; no gap can be computed for the estimate.
By their numbers in this assay, from the lowest: compounds 2 and 1 (each within the scatter of the next); then compound 3.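

In this assay, for the compounds shown here, compound 4 is reported as "not active" with no number, so no step from compound 3 to compound 4 can be read. Still open, going by these compounds, is whether the sulfonyl, the cyclohexyl or both matter for this result. No measurement shown here offers an explanation for it.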